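Swapping the hydroxyphenyl of compound 2 for a chlorophenyl

The source may hold more compounds than are shown below. What is called first, only, known or untested is meant among the compounds shown, and "the series" means these compounds.

The series shares one core, seen in compound 1 `Cc1cc(NC(=O)Nc2cccc(F)c2)c2ccccc2n1`, compound 2 `Cc1cc(NC(=O)Nc2ccc(O)cc2)c2ccccc2n1` and compound 3 `Cc1cc(NC(=O)Nc2ccc(OC(F)(F)F)cc2)c2ccccc2n1`. In a physicochemical assay for solubility, at pH 7.4 (a lower number here means a less soluble compound, a higher number a more soluble compound), compound 1 gives 100 nM, compound 2 gives 100 nM and compound 3 gives 300 nM. Compound 2 thus stands level with compound 1 and together they hold the lowest numbers; the step of a 3.0-fold higher number from compound 2 to compound 3 (0.48 log units; beyond the scatter) is the only one beyond the scatter. The unmeasured compound 4 `Cc1cc(NC(=O)Nc2cccc(Cl)c2)c2ccccc2n1` differs from compound 2 by 3-chlorophenyl in place of 4-hydroxyphenyl on an amide-type nitrogen. The step of no change at the digits printed from compound 1 to compound 2 (within the scatter) bears most directly on this change, and it was flat. Compound 4 is therefore expected to show no step beyond the scatter, no change at the digits printed from compound 2 to compound 4 (within the scatter), with an estimate of 100 nM in this assay, ranging from 40 nM to 250 nM.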

Compound 4, solubility: 800 nM
Beside the measured number, compound 4's estimate is 8.0-fold (0.90 log units) below it, and the stated range ends below it.
By their numbers in this assay, from the lowest: compounds 1 and 2 (each within the scatter of the next); then compound 3; then compound 4.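

At this amide-type nitrogen, the aryl group is not as indifferent as the flat step between compounds 1 and 2 suggested. Keeping the ring and its substitution place while putting chloro in place of fluoro on an aromatic carbon gives an 8.0-fold higher number from compound 1 to compound 4 (0.90 log units; beyond the scatter) in this assay, and the exchange of 4-hydroxyphenyl for 3-chlorophenyl gives an 8.0-fold higher number from compound 2 to compound 4 (0.90 log units; beyond the scatter). Nothing at hand explains this rise. Still open, going by these compounds, is how a 3-bromophenyl or 3-aminophenyl would read here. A 4-chlorophenyl would show whether the rise stays when the chloro group sits elsewhere on the ring.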